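A few compounds are considered here, and "the series" means these few. Any claim that something is new, unique, unknown or untested is made for them only; others in the source may bear on it.

Measured so far in an ADME assay on Vero 76 cells (Chlorocebus sabaeus) for cytotoxicity, read by microscopy; on this read-out higher numbers stand for lower toxicity in this test and lower numbers for higher toxicity in this test:
- compound 1, `CC(C)C(Nc1nc(Cl)nc2c1ncn2[C@H]1[C@H](O)[C@H](O)[C@]2(CO)C[C@H]12)C(C)C`: > 100000 nM
- compound 2, `OC[C@@]12C[C@@H]1[C@@H](n1cnc3c(NCc4ccccc4)nc(Cl)nc31)[C@H](O)[C@@H]2O`: > 100000 nM
- compound 3, `O[C@@H]1[C@H](O)[C@@H]2C[C@@H]2[C@H]1n1cnc2c(NC(C3CCC3)C3CCC3)nc(Cl)nc21`: 16000 nM

The values of compound 1 and compound 2 are limits of this assay, not numbers. Within the data shown here, compound 3 is the only compound here with a number; the two other values are limits, so there is no ordering among the three. Among the measured compounds shown here, the one step between measured compounds, a step that the two limits leave unreadable from compound 1 to compound 2, is unreadable, since both ends are limits.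

The next compound, compound 4, `OC[C@@]12C[C@@H]1[C@@H](n1cnc3c(NC(C4CCC4)C4CCC4)nc(Cl)nc31)[C@H](O)[C@@H]2O`, differs from compound 3 in this way: a group of 10 heavy atoms (7 carbon, 3 oxygen; one three-membered non-aromatic ring of carbon only, one five-membered non-aromatic ring of carbon only) in place of a group of 8 heavy atoms (6 carbon, 2 oxygen; one three-membered non-aromatic ring of carbon only, one five-membered non-aromatic ring of carbon only), on an aromatic nitrogen. For the measured compounds named here, no measured step covers this exact change, so nothing directly shows its size or direction. Compound 1 and compound 2 do carry the entering group, and compound 1 sits at the limit of > 100000 nM in this assay, at which 2 of the 3 values shown sit. Compound 2, with a different substituent on its amine nitrogen, sits at the same limit. This is consistent with, but does not prove, lower toxicity for compounds that carry the entering group.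

Compound 4 is therefore expected to give a half-maximal cytotoxic concentration of about 40000 nM, with a range of 12000 nM to 150000 nM. This estimate means a step of a 2.5-fold higher number from compound 3 to compound 4 (0.40 log units; beyond the scatter), and it may well be reported only as a limit.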

Compound 4, half-maximal cytotoxic concentration: 50000 nM
Estimate against measurement, compound 4: 1.3-fold (0.10 log units) below; measured number inside the range.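

In this assay, among these compounds, the first direct comparison at this position, on an aromatic nitrogen of the five-membered ring, keeps the dicyclobutylmethyl group on the amine nitrogen unchanged and puts the group of 10 heavy atoms in place of the group of 8 heavy atoms, giving a 3.1-fold higher number from compound 3 to compound 4 (0.49 log units; beyond the scatter) and thus lower toxicity in this test. Changing the substituent on the amine nitrogen while keeping the group of 10 heavy atoms gives an at least 2.0-fold lower number from compound 2 to compound 4 (0.30 log units; that floor lies within the scatter) and an at least 2.0-fold lower number from compound 1 to compound 4 (0.30 log units; that floor lies within the scatter), so dicyclobutylmethyl may be less well tolerated than benzyl or 1-isopropyl-2-methylpropyl, although both printed floors lie within the scatter and neither step settles this. The values of compound 1 and compound 2 remain limits of this assay, so the full size of these two steps stays hidden: the limit of > 100000 nM in this assay, at which 2 of the 4 values shown sit.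

The compounds shown leave open whether the group of 10 heavy atoms would bring a similar step with benzyl or 1-isopropyl-2-methylpropyl on the amine nitrogen. They also leave open what would happen if an amine or a carboxylic acid took the place of the extra carbon and oxygen in that group.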